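A few compounds are considered here, and "the series" means these few. Any claim that something is new, unique, unknown or untested is made for them only; others in the source may bear on it.

Three compounds share one core: compound 1 `CCOc1ccccc1-c1ccc(-c2nc3cnccc3c(NC(COC)C(N)=O)c2C#N)cc1`, compound 2 `CC(C)(CC(N)=O)c1c(C#N)c(-c2ccc(Br)cc2)nc2cnccc12` and compound 3 `CC[C@@H](Nc1c(C#N)c(-c2ccc(-c3ccc(OC)cc3)cc2)nc2cnccc12)C(N)=O`. In a physicochemical assay for lipophilicity, read by HPLC, at pH 7.5 (a higher number here means a more lipophilic compound, a lower number a more polar compound), compound 1 gives 2.8, the highest of the three numbers. Compound 3 gives 2.7, which lies within the scatter of compound 1, so no order between those two is drawn. Compound 2 gives 2.1, a number beyond the scatter lower than compound 1. Among the compounds with values here, no pair of measured compounds differs in one place only, so no single step in this assay has been read.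

Compound 4 `CCOc1ccccc1-c1ccc(-c2nc3cnccc3c(C[C@H](C)C(N)=O)c2C#N)cc1` is not yet measured in this assay. It differs from compound 1 in one place: 2-carbamoylpropyl in place of (1-carbamoyl-2-methoxyethyl)amino on an aromatic carbon. The group that leaves carries two hydrogen-bond donors and three acceptors, the group that enters one of each, as counted in that difference. Within the data shown here, with no measured one-place step to lean on, the size can only be expected. For compound 4 the step is expected to be small and upward, a number 0.30 log units higher from compound 1 to compound 4 (within the scatter), at the edge of the scatter. Compound 4 is estimated at 3.1, within 2.7 to 3.5.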

Compound 4, distribution coefficient: 3
Estimate against measurement, compound 4: 0.10 log units above; measured number inside the range.
By their numbers in this assay, from the lowest: compound 2; then compounds 3, 1 and 4 (each within the scatter of the next).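

Within the data shown here, the first one-place step in this assay can now be read, on the aromatic carbon ortho to a cyano group: 2-carbamoylpropyl in place of (1-carbamoyl-2-methoxyethyl)amino gives a number 0.20 log units higher from compound 1 to compound 4 (within the scatter) at this position. The entering group carries fewer heavy atoms, hydrogen-bond donors and hydrogen-bond acceptors than the leaving group, yet this assay does not separate the two compounds. Nothing available explains this step.

On these data alone, the step replaces the ring-bound amino nitrogen and the methoxy-bearing arm together, so the share of each remains open. Also open, as far as these compounds go, is whether a carboxylic acid in place of the carboxamide, or a longer chain ending in an amine, would give a step beyond the scatter at this position.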